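The compounds below may be only part of what the source reports. "The series", "measured", "known", "first", "only" and "open" are said of these compounds alone.

Three compounds share one core and differ only in the group carried on a saturated chain carbon bound to an aromatic nitrogen. Compound 1 `O=C1N[C@H]2[C@H](CS[C@H]2CCCCCc2cn(Cc3ccccc3O)nn2)N1` carries a 2-hydroxyphenyl there, compound 2 `COc1ccccc1Cn1cc(CCCCC[C@@H]2SC[C@@H]3NC(=O)N[C@@H]32)nn1` a 2-methoxyphenyl, and compound 3 `Cc1cccc(Cn2cc(CCCCC[C@@H]3SC[C@@H]4NC(=O)N[C@@H]43)nn2)c1` a 3-methylphenyl. In an assay on isolated protein for inhibition of biotin--protein ligase (Homo sapiens), read by scintillation counting, with a stated time of 10 min (a higher number here means a weaker inhibitor, a lower number a stronger inhibitor), compound 1 gives only a limit of > 16000 nM. In this assay compound 2 likewise gives a limit of > 16000 nM. Compound 3 also sits at a limit in this assay, > 16000 nM. The steps between them are therefore not readable: a step that the two limits leave unreadable from compound 1 to compound 2, a step that the two limits leave unreadable from compound 1 to compound 3 and a step that the two limits leave unreadable from compound 2 to compound 3. All that the measurements show is the limit of > 16000 nM in this assay, at which 3 of the 3 values shown sit. Compound 4 `O=C1N[C@H]2[C@H](CS[C@H]2CCCCCc2cn(Cc3ccccc3Br)nn2)N1` is the next variation: 2-bromophenyl in place of 3-methylphenyl on a saturated chain carbon bound to an aromatic nitrogen. Among the measured compounds shown here, none of the measured steps has a readable size, so there is no ground on which to expect a step beyond the scatter in either direction, and nothing to set compound 4 apart from the three compounds that sit at the limit. The step in this assay is accordingly expected to be a step that the limit leaves unreadable from compound 3 to compound 4. Compound 4 is expected to give about 25000 nM in this assay, within a range of 8000 nM to 80000 nM, and most likely to be reported again only as a limit.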

Compound 4, inhibition constant: > 16000 nM
Compound 4: a limit, no number; the forecaster's own chance of this, stated with the estimate: 80%; the middle value lies beyond the limit too.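

In this assay, among the compounds shown here, compound 4 gives > 16000 nM as a limit and not a number, so no step from compound 1, compound 2 or compound 3 to compound 4 can be read. The compounds shown leave open whether the groups compared here separate these compounds at all in this assay and what their actual values are.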